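This account rests on a few compounds, and the source may have more. Where it says the series, first, only, none or still open, it means among the compounds named here.

Compound 1 `Cc1ccc(S(=O)(=O)Nc2ccc3ncc(-c4cnn(C)c4)cc3n2)cc1` and compound 2 `Cn1cc(-c2cnc3ccc(NS(=O)(=O)c4cccs4)nc3c2)cn1` share one core, while compound 3 `Cc1ccc(S(=O)(=O)Nc2nccc3ncc(-c4cnn(C)c4)cc23)cc1` is built from the same atoms joined differently; how the two cores differ is not broken down here. In a functional assay on A549 cells (Homo sapiens) for antiproliferative activity, read by MTT assay, with a stated time of 48 h (a lower number here means a stronger inhibitor, a higher number a weaker inhibitor), compound 1 gives 45500 nM. In this assay compound 2 gives 39500 nM. The change between them is thiophen-2-yl in place of 4-methylphenyl on a sulfonyl sulfur and it made a 1.2-fold lower number from compound 1 to compound 2 (0.06 log units; within the scatter). For compound 3 the result is only a limit, > 50000 nM, and that limit is recorded as the limit of > 50000 nM in this assay, at which 1 of the 3 values shown sits.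

Compound 4 `Cn1cc(-c2cnc3ccnc(NS(=O)(=O)c4cccs4)c3c2)cn1` carries the core of compound 3 and stands to it as compound 2 stands to compound 1: the change is thiophen-2-yl in place of 4-methylphenyl on a sulfonyl sulfur, the same change, made at the same kind of place. It has not yet been measured in this assay.

Since the step from compound 1 to compound 2 stayed within the scatter, the same change on the core of compound 3 is expected to move the value little, so compound 4 is estimated to give 55000 nM in this assay, with the step that the limit leaves unreadable from compound 3 to compound 4 expected to be small. Because compound 3 itself sits at the limit (the limit of > 50000 nM in this assay, at which 1 of the 3 values shown sits), it is thought likely that compound 4 will also be reported only as a limit, and the expected range for compound 4 runs from 30000 nM to 120000 nM.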

Compound 4, half-maximal inhibitory concentration: 9400 nM
Compound 4: middle estimate off by 5.9-fold (0.77 log units), on the high side; measured number below the stated range.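

In this assay, thiophen-2-yl in place of 4-methylphenyl on a sulfonyl sulfur gave an at least 5.3-fold lower number from compound 3 to compound 4 (0.72 log units; beyond the scatter), so this change did not carry over from one core to the other with the same size: the same change on two cores in this assay, a 1.2-fold lower number (0.06 log units; within the scatter) from compound 1 to compound 2 and an at least 5.3-fold lower number (0.72 log units; beyond the scatter) from compound 3 to compound 4, at least 4.6-fold (0.66 log units) apart, beyond the scatter of two such steps

Compound 3 is recorded only as a limit, > 50000 nM, so the step on its core has a known minimum but no exact size: the limit of > 50000 nM in this assay, at which 1 of the 4 values shown sits.

The result shows that, for these two pairs, the size of the change depended on the core it was made on, but two pairs establish no rule for the series, and they do not show what it is about the two cores that separates the steps, nor whether compound 4 owes its value to any particular property of thiophen-2-yl.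

The compounds shown leave open whether other groups on the sulfonyl sulfur, such as a simple methyl, a furan-2-yl or a phenyl ring carrying a carboxylic acid or an amine, would also separate the two cores in this way. They also leave open whether the difference between the cores would persist if an amide took the place of the sulfonamide.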